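The source may report more compounds than this note shows. Statements on the series, on what has been measured and on what is new or still open speak of the compounds shown alone.

Measured compounds:
compound 1 `O=C(CCCCCCc1ccccc1)c1ncc(-c2ccc(O)cc2)o1` with 140 nM in an assay (Rattus norvegicus) for inhibition of Fatty-acid amide hydrolase 1 (Homo sapiens); on this read-out lower numbers stand for stronger inhibition and higher numbers for weaker inhibition;
compound 2 `Cc1ccc(-c2cnc(C(=O)CCCCCCc3ccccc3)o2)nc1` with 2.8 nM in this assay.

Compound 2 stands at the lowest of the two numbers in this assay; its nearest neighbour is compound 1, reached by a 50-fold lower number from compound 1 to compound 2 (1.70 log units; beyond the scatter), a step brought about by putting 5-methylpyridin-2-yl in place of 4-hydroxyphenyl on an aromatic carbon. Compound 3 `COc1ccnc(-c2cnc(C(=O)CCCCCCc3ccccc3)o2)c1` has not yet been measured in this assay. It differs from compound 2 by 4-methoxypyridin-2-yl in place of 5-methylpyridin-2-yl on an aromatic carbon. Among the measured compounds shown here, no measured step swaps one pyridin-2-yl group for another; the only step known, from compound 1 to compound 2, replaced a phenyl bearing a hydroxyl with a pyridyl, and compound 3 keeps the pyridyl. The change is therefore expected to stay within the scatter, with no clear direction. The expected step is a 1.8-fold higher number from compound 2 to compound 3 (0.25 log units; within the scatter). Compound 3 is accordingly expected to give about 5 nM in this assay, most likely between 1.5 nM and 20 nM.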

Compound 3, inhibition constant: 0.8 nM
The estimate for compound 3 lay 6.3-fold (0.80 log units) above the measured number; the whole stated range lies above it.
By their numbers in this assay, from the lowest: compound 3; then compound 2; then compound 1.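

In this assay, this position, on an aromatic carbon next to the ring oxygen, responds not only to replacing the 4-hydroxyphenyl group but also to a change between two pyridin-2-yl groups: 4-methoxypyridin-2-yl in place of 5-methylpyridin-2-yl gives a 3.5-fold lower number from compound 2 to compound 3 (0.54 log units; beyond the scatter), a modest step but a real one. Set against the 4-hydroxyphenyl group, the 4-methoxypyridin-2-yl group gives a 180-fold lower number from compound 1 to compound 3 (2.24 log units; beyond the scatter), so the large step seen with compound 2 is not the limit of what a pyridin-2-yl group can do here. Nothing available explains the difference between the two pyridin-2-yl groups.

Because the substituent and its place on the pyridin-2-yl group change together, the compounds shown cannot separate the two. As far as these compounds go, how a 4-methylpyridin-2-yl or 5-methoxypyridin-2-yl group, or an amine or carboxylic acid on that group, would read remains open.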